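The source may hold more compounds than are shown below. What is called first, only, known or untested is meant among the compounds shown, and "the series" means these compounds.

Measured so far:
compound 1, `CCCCCCCCN(C)C(=O)Cn1cc(Cc2cnc(=O)n(C)c2)c(=O)nc1SCc1ccc(F)cc1`: in a functional assay on a cell-free system (plasma) for inhibition of platelet-activating factor acetylhydrolase (Homo sapiens), tested at 100 nM (on this read-out lower numbers stand for less inhibition and higher numbers for more inhibition at the one concentration tested (going by the name of the read-out)), compound 1 gives 55%.
compound 2, `CCCCCCCCN(C)C(=O)Cn1cc(Cc2cnc(=O)n(CC(=O)N3CCN(C)CC3)c2)c(=O)nc1SCc1ccc(F)cc1`: in this assay compound 2 gives 68%.

Compound 2 stands highest of the two numbers. Within the data shown here, the one measured step is a number 13 percentage points higher from compound 1 to compound 2 (beyond the scatter).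

Compound 3, `CCCCCCCCN(C)C(=O)Cn1cc(Cc2cnc(=O)n(CC(=O)N3CCNC(=O)C3)c2)c(=O)nc1SCc1ccc(F)cc1`, differs from compound 2 by 3-oxopiperazin-1-yl in place of 4-methylpiperazin-1-yl on a carbonyl carbon. Among the measured compounds shown here, no measured step bears directly on this exchange; the only step known concerns adding the whole (4-methylpiperazin-1-yl)carbonyl, so the effect of exchanging the ring within it is open. A step not beyond the scatter is therefore expected, with a wide range. For compound 3 the expected value in this assay is 62%, within 42% to 78%. The step thus expected is a number 6 percentage points lower from compound 2 to compound 3 (within the scatter).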

Compound 3, a percentage reported as inhibition, at one concentration (the size of the read-out at that concentration, not a potency): 80%
For compound 3 the middle estimate is 18 percentage points below the measured one; the whole stated range lies below it.
By their numbers in this assay, from the lowest: compound 1; then compound 2; then compound 3.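

In this assay, 3-oxopiperazin-1-yl in place of 4-methylpiperazin-1-yl on the carbonyl carbon gives a number 12 percentage points higher from compound 2 to compound 3 (beyond the scatter), so the ring itself counts here, not only the presence of a (4-methylpiperazin-1-yl)carbonyl-type group. Against hydrogen on the saturated chain carbon, (3-oxopiperazin-1-yl)carbonyl gives a number 25 percentage points higher from compound 1 to compound 3 (beyond the scatter), the larger of the two steps from compound 1. Nothing at hand explains the difference between the two rings.

Going by these compounds, whether the amide hydrogen of the 3-oxopiperazin-1-yl ring is needed remains open. Also open, on these data alone, is what morpholin-4-yl or a plain dimethylamino group would give on the same carbonyl carbon.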